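Shifting a Methyl on the Aryl Amide of Compound 1

A few compounds are considered here, and "the series" means these few. Any claim that something is new, unique, unknown or untested is made for them only; others in the source may bear on it.

Compound 1 `Cc1cccc(C(=O)NC(CCN(C)C)c2ccc(Cl)cc2)c1C` was tested in an assay on NIH3T3 cells with Urotensin-2 receptor (Homo sapiens) as the target (a lower number here means a smaller maximal response, a higher number a larger maximal response), where compound 1 reaches 159%. Compound 2 `COc1cccc(C(=O)NC(CCN(C)C)c2ccc(Cl)cc2)c1C` reaches 179% in this assay. Of these two numbers compound 1 holds the lower one; the gap is a number 20 percentage points higher from compound 1 to compound 2 (beyond the scatter), and the two compounds differ by a methoxy in place of a methyl on an aromatic carbon.

Compound 3 `Cc1ccc(C(=O)NC(CCN(C)C)c2ccc(Cl)cc2)c(C)c1` has not yet been measured. From compound 1 it differs in this way: 2,4-dimethylphenyl in place of 2,3-dimethylphenyl on a carbonyl carbon. Going by the values given here, the one measured step exchanges a group for another kind of group, whereas compound 3 keeps the same atoms and only joins them differently, so that step gives no direct guide. Among the compounds with values here, with no comparable precedent, a change in this assay no larger than the scatter is expected, in no particular direction. For compound 3 a maximal response near 160% is therefore expected, within a range from 120% to 200%, which means an expected step of a number 1 percentage points higher from compound 1 to compound 3 (within the scatter).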

Compound 3, largest response reached (reported as efficacy), in percent of the reference or control that the assay uses: 147%
The estimate for compound 3 lay 13 percentage points above the measured number; low and high end bracket the measured number.
By their numbers in this assay, from the lowest: compound 3; then compound 1; then compound 2.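

Compounds 1 and 3 carry the same atoms, so swapping 2,3-dimethylphenyl for 2,4-dimethylphenyl on a carbonyl carbon changes only how those atoms are joined, yet it still gives a number 12 percentage points lower from compound 1 to compound 3 (beyond the scatter) in this assay as a measured shift. The maximal response at this position therefore depends on where a methyl sits on the ring, not only on which groups are present, and this rearrangement lowers the number, whereas the methoxy exchange in compound 2 raised it. No available measurement bears on why the response moves in this way.

The two steps leave open what an unsubstituted phenyl or a 2,6-dimethylphenyl on the same carbonyl carbon would give. As far as these compounds go, it also remains open whether methoxy would respond to a shift around the ring as methyl does here.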